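Pyrimidinyl thiourea series: dimethyl to dimethoxy step

The source may report more compounds than this note shows. Statements on the series, on what has been measured and on what is new or still open speak of the compounds shown alone.

Compound 1 `COc1cc(SC)nc(NC(=S)NC(=O)c2c(-c3ccc(Cl)cc3Cl)noc2C)n1` carries a 4-methoxy-6-(methylsulfanyl)pyrimidin-2-yl group and gives 18.7% in a functional assay on the whole organism for inhibition, with Brassica napus as the target, with a stated time of 72 h, tested at 10 mg/L; on this read-out lower numbers stand for less inhibition of growth and higher numbers for more inhibition of growth at the one concentration tested. Compound 2 `Cc1cc(C)nc(NC(=S)NC(=O)c2c(-c3ccc(Cl)cc3Cl)noc2C)n1` carries 4,6-dimethylpyrimidin-2-yl in the same position; in this assay compound 2 gives 16.1%. The step is a number 2.6 percentage points lower from compound 1 to compound 2 (within the scatter), so the two numbers lie within the usual scatter of each other and compound 2 cannot be set apart from compound 1 on the numbers at hand.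

Compound 3 `COc1cc(OC)nc(NC(=S)NC(=O)c2c(-c3ccc(Cl)cc3Cl)noc2C)n1` is the next member. The change is 4,6-dimethoxypyrimidin-2-yl in place of 4,6-dimethylpyrimidin-2-yl on an amide-type nitrogen. Among the compounds with values here, the only measured step that bears on it is the exchange at the same nitrogen between compound 1 and compound 2, a number 2.6 percentage points lower from compound 1 to compound 2 (within the scatter), which left the read-out essentially unmoved. With a single step, itself within the scatter, no direction can be read from the series, and the step from compound 2 to compound 3 is therefore expected to stay within the scatter as well, a number 1.9 percentage points higher from compound 2 to compound 3 (within the scatter). Compound 3 is accordingly expected to give about 18% in this assay, with a range from 7% to 32%.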

Compound 3, percent growth inhibition at one concentration: 35.2%
For compound 3 the middle estimate is 17.2 percentage points below the measured one; the whole stated range lies below it.
By their numbers in this assay, from the lowest: compounds 2 and 1 (each within the scatter of the next); then compound 3.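

In this assay the group on the amide-type nitrogen no longer looks indifferent: 4,6-dimethoxypyrimidin-2-yl in place of 4,6-dimethylpyrimidin-2-yl gives a number 19.1 percentage points higher from compound 2 to compound 3 (beyond the scatter) and thus a step that the earlier exchange at this nitrogen did not show. Methoxy in place of methylsulfanyl on an aromatic carbon gives a number 16.5 percentage points higher from compound 1 to compound 3 (beyond the scatter), so among these three compounds only the group with two methoxy substituents stands apart, while compound 1, with one methoxy and one methylsulfanyl, stays within the scatter of compound 2, with two methyl groups. Nothing at hand gives a reason for this step.

From the compounds shown here alone, whether the rise is tied to methoxy itself stays open, since ethoxy, dimethylamino or chloro in place of one or both methoxy groups would be needed to show how narrow the requirement is. Also open, going by these compounds, is whether the 4,6-dimethoxypyrimidin-2-yl group keeps its advantage on a changed core or at other concentrations, as all three numbers come from one concentration on one plant species.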